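The source may report more compounds than this note shows. Statements on the series, on what has been measured and on what is new or still open speak of the compounds shown alone.

Measured so far:
compound 1 `CC(=O)c1[se]c(N/N=C/c2csc(-c3ccccc3)n2)nc1C`: 49900 nM
compound 2 `CCOC(=O)c1[se]c(N(/N=C/c2ccc(Cl)cc2)C(C)=O)nc1C`: > 60500 nM

In a functional assay on DU-145 cells (Homo sapiens) for cytotoxicity, read by XTT assay, with a stated time of 72 h (a lower number here means a stronger inhibitor, a higher number a weaker inhibitor), compound 1 gives 49900 nM. Compound 2 was reported in this assay only as a limit, > 60500 nM, namely (the limit of > 60500 nM in this assay, at which 1 of the 2 values shown sits). Compound 1 therefore holds the only real number shown, and it is a weak one. Compound 3 `CC(=O)c1[se]c(N(/N=C/c2csc(-c3ccccc3)n2)C(C)=O)nc1C` is not yet measured; it differs from compound 1 by acetyl in place of hydrogen on a nitrogen on an aromatic ring. No measured step of this kind is shown, so the expected step in this assay, from compound 1 to compound 3, is estimated at a 1.5-fold higher number from compound 1 to compound 3 (0.18 log units; within the scatter), leaning toward weaker rather than stronger. Compound 3 is expected to give about 75000 nM, between 30000 nM and 200000 nM, with a fair chance that only a limit is reported.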

Compound 3, half-maximal inhibitory concentration: 31300 nM
Estimate against measurement, compound 3: 2.4-fold (0.38 log units) above; low and high end bracket the measured number.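

In this assay, within the data shown here, acetyl in place of hydrogen on a nitrogen on an aromatic ring gives the first comparison of two real numbers that differ in one place (a 1.6-fold lower number from compound 1 to compound 3 (0.20 log units; within the scatter)). This nitrogen can therefore carry acetyl with no shift that stands out from the scatter, and the hydrogen there is not needed to keep this weak activity. No measurement shown explains the step.

Going by these compounds, whether a methyl group, a benzoyl group or a longer chain such as butanoyl on this nitrogen would move the number beyond the scatter stays open.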